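The source may hold more compounds than are shown below. What is called first, only, known or untested is meant among the compounds shown, and "the series" means these compounds.

Working notes on the series. Of the compounds shown here, three of one shared core have been measured in an ADME assay on NIH3T3 cells (Mus musculus) for cytotoxicity, read by MTT assay, with a stated time of 24 h; a lower number here means a stronger inhibitor, a higher number a weaker inhibitor. Compound 1 `O=C(CSc1nnc(-c2ccncc2)o1)N/N=C/c1ccc(F)cc1` gives 170000 nM. Compound 2 `O=C(CSc1nnc(-c2ccncc2)o1)N/N=C/c1ccc(Cl)cc1` gives 181000 nM. Compound 3 `O=C(CSc1nnc(-c2ccncc2)o1)N/N=C/c1ccc(Br)cc1` gives 169000 nM. The halogen swaps move nothing beyond the scatter: a 1.1-fold higher number from compound 1 to compound 2 (0.03 log units; within the scatter), a 1.0-fold lower number from compound 1 to compound 3 (0.00 log units; within the scatter) and a 1.1-fold lower number from compound 2 to compound 3 (0.03 log units; within the scatter). Compound 3 therefore stands in one group with compound 1 and compound 2, separated from neither.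

Compound 4 `O=C(CSc1nnc(-c2ccncc2)o1)N/N=C/c1ccc([N+](=O)[O-])cc1` differs from compound 3 in one place: nitro in place of bromo on an aromatic carbon. Going by the values given here, no measured step replaces a halogen with nitro; the three steps that bear on this position all exchange one halogen for another and all lie within the scatter, so they show only that this position has tolerated exchange without a shift in this assay. On that footing, compound 4 is expected to give a number close to that of compound 3, with the step of a 1.0-fold higher number from compound 3 to compound 4 (0.00 log units; within the scatter) taken as no step beyond the scatter. The estimate for compound 4 in this assay is 170000 nM, with a range from 80000 nM to 360000 nM, the range widened to allow for the untested nature of the nitro exchange.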

Compound 4, half-maximal inhibitory concentration: 195000 nM
Beside the measured number, compound 4's estimate is 1.1-fold (0.06 log units) below it, within the range that was stated.
By their numbers in this assay, from the lowest: compounds 3, 1, 2 and 4 (each within the scatter of the next).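

The earlier steps shown here at this position only exchanged one halogen for another, so they said nothing about a group of a different kind. Nitro brings more heavy atoms and carries hydrogen-bond acceptors, yet in this assay all three exchanges for it lie within the scatter (a 1.2-fold higher number from compound 3 to compound 4 (0.06 log units; within the scatter)) (a 1.1-fold higher number from compound 2 to compound 4 (0.03 log units; within the scatter)) (a 1.1-fold higher number from compound 1 to compound 4 (0.06 log units; within the scatter)), so tolerance at this position extends beyond the halogens to this one non-halogen group. No supporting measurement bears on why the number in this assay is insensitive to these exchanges.

As far as these compounds go, whether this tolerance holds for an amine, a carboxylic acid or a longer alkyl chain at this position remains open. Also open, from the compounds shown here alone, is whether exchanges elsewhere on the shared core would shift the number in this assay beyond the scatter.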